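Chloroacetyl ester of the free hydroxyl compound

This account rests on a few compounds, and the source may have more. Where it says the series, first, only, none or still open, it means among the compounds named here.

Compound 2 `C=C1C2=C(C(=O)N1OC)[C@H](O)[C@@](C)(O)[C@H](CCCCC)O2` carries a free hydroxyl group on the shared core. In a functional assay on A549 cells (Homo sapiens) for cytotoxicity, read by sulforhodamine B assay, with a stated time of 48 h (a higher number here means that more compound is needed for the effect, a lower number that less compound is needed), compound 2 gives 46000 nM. Among the compounds with values here, that is the lowest of the two numbers measured so far, but its only neighbour, compound 1 `C=C1C2=C(C(=O)N1OC)[C@H](OC(C)=O)[C@@](C)(O)[C@H](CCCCC)O2`, which carries an acetyl group on that same oxygen, gives 49000 nM, and the step of a 1.1-fold lower number from compound 1 to compound 2 (0.03 log units; within the scatter) is within the scatter, so the two compounds cannot be told apart on these data.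

Compound 3 `C=C1C2=C(C(=O)N1OC)[C@H](OC(=O)CCl)[C@@](C)(O)[C@H](CCCCC)O2` differs from compound 2 by (chloromethyl)carbonyl in place of hydrogen on an oxygen on a saturated carbon. Within the data shown here, the one measured step that speaks to this change is the exchange of acetyl for hydrogen on this same oxygen, and it moved the number by only a 1.1-fold lower number from compound 1 to compound 2 (0.03 log units; within the scatter), within the scatter. Since an ester at this position left the number unchanged there, a (chloromethyl)carbonyl ester is expected to behave much the same, so no step beyond the scatter is expected in this assay for compound 3 as a 1.0-fold lower number from compound 2 to compound 3 (0.01 log units; within the scatter). For compound 3 the estimate in this assay is 45000 nM, with a range from 20000 nM to 100000 nM.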

Compound 3, half-maximal effective concentration: 33000 nM
Compound 3: the middle estimate sits 1.4-fold (0.13 log units) above what was measured; the range from low to high includes it.
By their numbers in this assay, from the lowest: compounds 3, 2 and 1 (each within the scatter of the next).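

In this assay, the step of a 1.4-fold lower number from compound 2 to compound 3 (0.14 log units; within the scatter) means that the free hydroxyl and the (chloromethyl)carbonyl ester on this oxygen cannot be told apart, so a second ester, not just the acetyl one, stays within the scatter of the free hydroxyl. The step of a 1.5-fold lower number from compound 1 to compound 3 (0.17 log units; within the scatter) adds something the earlier pair could not show: it compares two esters directly, and chloro in place of hydrogen on a saturated chain carbon bound to a carbonyl carbon also stays within the scatter. No measurement at hand offers an explanation for this even picture at this position.

From the compounds shown here alone, what remains open is whether an ester of a different kind on this oxygen, such as a benzoyl ester, an ester with a longer chain or one carrying an amine, would move the number beyond the scatter. Going by these compounds, it is also open whether changes elsewhere on the shared core would matter more in this assay than these exchanges on this oxygen have.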